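A few compounds are considered here, and "the series" means these few. Any claim that something is new, unique, unknown or untested is made for them only; others in the source may bear on it.

Compound 1, `Cc1cccc(NC(=O)C(F)(F)C(F)(F)C(F)(F)C(F)(F)C(F)(F)C(F)(F)C(=O)NO)c1`, is tested in an ADME assay on isolated protein for inhibition of histone deacetylase 4 (Homo sapiens), read by fluorescence, with stated times of 30 min and 60 min (a higher number here means a weaker inhibitor, a lower number a stronger inhibitor), and returns only the limit > 50000 nM rather than a number. Compound 2, `O=C(NO)C(F)(F)C(F)(F)C(F)(F)C(F)(F)C(F)(F)C(F)(F)C(=O)Nc1ccc(I)cc1`, likewise gives only the limit > 50000 nM in this assay. Compound 3, `O=C(NO)C(F)(F)C(F)(F)C(F)(F)C(F)(F)C(F)(F)C(F)(F)C(=O)Nc1ccccc1-c1ccccc1`, also sits at the limit > 50000 nM in this assay. The step from compound 1 to compound 2 is a step that the two limits leave unreadable from compound 1 to compound 2, the step from compound 1 to compound 3 is a step that the two limits leave unreadable from compound 1 to compound 3, and the step from compound 2 to compound 3 is a step that the two limits leave unreadable from compound 2 to compound 3, all three values sharing (the limit of > 50000 nM in this assay, at which 3 of the 3 values shown sit). Compound 4, `O=C(NO)C(F)(F)C(F)(F)C(F)(F)C(F)(F)C(F)(F)C(F)(F)C(=O)Nc1cccc(-c2cn(-c3ccccc3)nn2)c1`, differs from compound 1 by 1-phenyl-1H-1,2,3-triazol-4-yl in place of methyl on an aromatic carbon. Given that compound 1 stands at the limit of > 50000 nM in this assay, at which 3 of the 3 values shown sit, compound 4 is expected to show a step of a number no higher from compound 1 to compound 4 (the limit leaves the size open) with no readable direction. The estimate for compound 4 is 50000 nM, ranging from 15000 nM to 200000 nM.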

Compound 4, inhibition constant: > 50000 nM
Compound 4: a limit, no number; the forecaster's own chance of this, stated with the estimate: 80%; the middle value lies on the limit itself.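

In this assay, among these compounds, compound 4 gives only the limit > 50000 nM and no number, so no step from compound 1 to compound 4 can be read. The compounds shown leave open how strongly any of them inhibits and how they rank against one another.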